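Dropping One Methoxy Group: Effect on Aromatase Inhibition

The source may report more compounds than this note shows. Statements on the series, on what has been measured and on what is new or still open speak of the compounds shown alone.

Two phenolic compounds have so far been tested in an assay for inhibition of Aromatase (Homo sapiens), using microsomes; a higher number here means a weaker inhibitor, a lower number a stronger inhibitor. Compound 1 `COc1cc(/C=C/C(=O)OC/C(C)=C/Cc2c(O)ccc(C(=O)/C=C/c3ccc(O)cc3O)c2O)ccc1O` gives 7100 nM. Compound 2 `CC(C)=CCC/C(C)=C/Cc1c(-c2ccc(O)cc2O)oc2cc(O)cc(O)c2c1=O` gives 24000 nM. Of these two numbers, compound 1 has the lower one, so it is the stronger inhibitor of the pair, and its distance to compound 2 lies beyond the usual scatter.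

Compound 3 `C/C(=C\Cc1c(O)ccc(C(=O)/C=C/c2ccc(O)cc2O)c1O)COC(=O)/C=C/c1ccc(O)cc1` has not yet been measured. It differs from compound 1 in a single spot: hydrogen in place of methoxy on an aromatic carbon. In plain words, hydrogen takes the place of a methoxy on an aromatic carbon, so the 4-hydroxy-3-methoxyphenyl end of compound 1 becomes a 4-hydroxyphenyl end in compound 3.

Among the compounds with values here, no measured pair in this set shows what such a change does here, so the size of the step has to be judged from the change alone: a methoxy leaves, a hydrogen enters, and nothing else moves. The step from compound 1 to compound 3 is expected to be modest, a 1.1-fold higher number from compound 1 to compound 3 (0.02 log units; within the scatter), with no clear direction beyond the scatter. Compound 3 is therefore estimated at 7500 nM, within a range of 2500 nM to 22000 nM.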

Compound 3, half-maximal inhibitory concentration: 500 nM
Compound 3: middle estimate off by 15-fold (1.18 log units), on the high side, outside the stated range (below it).
By their numbers in this assay, from the lowest: compound 3; then compound 1; then compound 2.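

Taking the methoxy off the 4-hydroxy-3-methoxyphenyl end turns out to be far from a minor edit in this assay: the change to a 4-hydroxyphenyl end gives a 14-fold lower number from compound 1 to compound 3 (1.15 log units; beyond the scatter), which means a clearly stronger inhibitor. This aromatic carbon, ortho to a hydroxy group and meta to a large group, is therefore a sensitive spot, since a methoxy of only 2 heavy atoms, carrying 1 hydrogen-bond acceptor, is the whole difference between the two structures. Nothing measured here explains why the compound with hydrogen at this spot is the stronger inhibitor.

The compounds shown leave open whether only hydrogen works at this carbon, or whether a fluorine or an ethoxy group there would keep the number close to that of compound 3 or return it towards that of compound 1. Going by these compounds, it also remains open whether a step of this size would survive elsewhere in the structure, for instance with an amide in place of the ester of compound 3.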